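The source may report more compounds than this note shows. Statements on the series, on what has been measured and on what is new or still open speak of the compounds shown alone.

Measured so far:
compound 1, `CCCCOc1ccc2c(Cl)ccnc2c1`: 3610 nM
compound 2, `CCCCCCCCOc1ccc2c(Cl)ccnc2c1`: 4300 nM
compound 3, `CCOc1ccc2c(Cl)ccnc2c1`: 3910 nM

All three were run in a functional assay on BGC-823 cells (Homo sapiens) for cytotoxicity, read by MTT assay, with a stated time of 48 h; a higher number here means a weaker inhibitor, a lower number a stronger inhibitor. Compound 3 stands second highest of the three numbers; its nearest neighbour is compound 1, with a 1.1-fold higher number from compound 1 to compound 3 (0.03 log units; within the scatter), and its furthest is compound 2, with a 1.1-fold lower number from compound 2 to compound 3 (0.04 log units; within the scatter), so the three sit together within the scatter.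

Compound 4, `Clc1ccnc2cc(OCCCc3ccccc3)ccc12`, has not yet been measured. It differs from compound 3 by benzyl in place of hydrogen on a saturated chain carbon, two bonds along the chain from an oxygen on an aromatic ring. Among the compounds with values here, the steps that bear on this place are the two ending at compound 3: a 1.1-fold higher number from compound 1 to compound 3 (0.03 log units; within the scatter) and a 1.1-fold lower number from compound 2 to compound 3 (0.04 log units; within the scatter). Further along the same chain, a 1.2-fold higher number from compound 1 to compound 2 (0.08 log units; within the scatter) is also within the scatter. Nothing here shows the chain on the oxygen moving the number beyond the scatter, so compound 4 is expected to give a step of a 1.0-fold lower number from compound 3 to compound 4 (0.00 log units; within the scatter), that is, none beyond the scatter. Compound 4 is therefore estimated at 3900 nM, with a range from 1800 nM to 8500 nM.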

Compound 4, half-maximal inhibitory concentration: 2370 nM
For compound 4 the middle estimate is 1.6-fold (0.22 log units) above the measured one; the measured number falls inside the stated range.
By their numbers in this assay, from the lowest: compounds 4, 1, 3 and 2 (each within the scatter of the next).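

In this assay, within the data shown here, the phenyl-ended chain of compound 4 is the first aromatic ring placed on the chain, yet benzyl in place of hydrogen on a saturated chain carbon gives a step within the scatter (a 1.6-fold lower number from compound 3 to compound 4 (0.22 log units; within the scatter)). Phenyl in place of pentyl (a 1.8-fold lower number from compound 2 to compound 4 (0.26 log units; within the scatter)) and phenyl in place of methyl (a 1.5-fold lower number from compound 1 to compound 4 (0.18 log units; within the scatter)) also stay within the scatter, so at this position neither chain length nor a terminal phenyl separates the four compounds. No measurement is available to explain these small steps.

As far as these compounds go, it remains open whether an amine or a carboxylic acid at the end of the chain would move the number beyond the scatter. The chlorine on the shared core is also unchanged throughout, so these compounds say nothing about replacing it.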